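The source may hold more compounds than are shown below. What is called first, only, known or untested is meant among the compounds shown, and "the series" means these compounds.

Compound 3 `CC1=C(C(=O)OCC2CCC2)C(c2ccoc2)NC(=O)N1` gives 739 nM in an assay on membranes from HEK293 cells for displacement of a labelled ligand from adenosine receptor A2b (Homo sapiens), read by scintillation counting, with a stated time of 30 min (on this read-out lower numbers stand for stronger inhibition and higher numbers for weaker inhibition), the highest of the three numbers measured. Compound 1 `CC1=C(C(=O)OCC2CCC2)C(c2ccco2)NC(=O)N1` gives 561 nM in this assay, and the step of a 1.3-fold higher number from compound 1 to compound 3 (0.12 log units; within the scatter) lies within the scatter. Compound 2 `CC1=C(C(=O)OC2CCC2)C(c2ccoc2)NC(=O)N1` gives 307 nM in this assay, and the step of a 2.4-fold higher number from compound 2 to compound 3 (0.38 log units; beyond the scatter) is modest. Compound 4 `CC1=C(C(=O)OCC2CCC2)C(c2ccsc2)NC(=O)N1` differs from compound 3 by thiophen-3-yl in place of furan-3-yl on a saturated ring carbon. Among the compounds with values here, neither measured step bears directly on this change: one exchanges furan-2-yl for furan-3-yl, the other cyclobutyl for cyclobutylmethyl, and no measured step exchanges one ring heteroatom for another. Compound 4 is therefore expected to give 600 nM in this assay, between 250 nM and 1500 nM. The expected step of a 1.2-fold lower number from compound 3 to compound 4 (0.09 log units; within the scatter) is thus not expected to go beyond the scatter.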

Compound 4, inhibition constant: 1040 nM
Beside the measured number, compound 4's estimate is 1.7-fold (0.24 log units) below it; measured number inside the range.
By their numbers in this assay, from the lowest: compounds 2, 1, 3 and 4 (each within the scatter of the next, the first and the last beyond it).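

In this assay, within the data shown here, replacing the ring oxygen of furan-3-yl with the sulfur of thiophen-3-yl on this saturated ring carbon gives a 1.4-fold higher number from compound 3 to compound 4 (0.15 log units; within the scatter), the first measured exchange of one ring heteroatom for another at this position. With the cyclobutylmethyl ester held constant, the step from furan-2-yl to thiophen-3-yl also stays inside the scatter, at a 1.9-fold higher number from compound 1 to compound 4 (0.27 log units; within the scatter). Nothing available explains these results. The compounds shown leave open whether phenyl or thiophen-2-yl on this carbon would also stay within the scatter. They also leave open whether thiophen-3-yl would behave alike with cyclobutyl on the ester oxygen.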